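The compounds below may be only part of what the source reports. "The series", "measured", "known", "first", "only" and "open" are said of these compounds alone.

Measured compounds:
Compound 1 `Cc1ccc(N2C(=O)C=CC2OCC(F)(F)F)cc1` gives 7140 nM
Compound 2 `O=C1C=CC(OC(C(F)(F)F)C(F)(F)F)N1c1ccc(Cl)cc1` gives 4480 nM

Among the measured compounds shown here, in a functional assay on K562 cells (Homo sapiens) for inhibition (a lower number here means a stronger inhibitor, a higher number a weaker inhibitor), compound 1 stands at the higher of the two numbers recorded so far, with compound 2 its only neighbour. The gap between the two lies within the usual scatter of this assay, so the two values show no real difference in inhibitory strength; neither compound can be called the stronger or the weaker of the pair.

Compound 3 `CC(C)(C)c1ccc(N2C(=O)C=CC2OCC(F)(F)F)cc1` has not yet been measured. It differs from compound 1 in one place: tert-butyl in place of methyl on an aromatic carbon. For the measured compounds named here, no measured pair in this set shows what such an exchange does, so the expectation must rest on compound 1 alone. The step from compound 1 to compound 3 is expected to be a 1.0-fold lower number from compound 1 to compound 3 (0.01 log units; within the scatter), a change no larger than the ordinary scatter of repeat measurements, in no particular direction. Compound 3 is therefore expected to give about 7000 nM in this assay, with a plausible range from 2500 nM to 20000 nM.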

Compound 3, half-maximal inhibitory concentration: 70 nM
Compound 3: middle estimate off by 100-fold (2.00 log units), on the high side; measured number outside the range, below it.
By their numbers in this assay, from the lowest: compound 3; then compounds 2 and 1 (each within the scatter of the next).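

In this assay, putting tert-butyl in place of methyl on an aromatic carbon, para to a large group, gives a 100-fold lower number from compound 1 to compound 3 (2.01 log units; beyond the scatter), a large step and the first one beyond the scatter in this set. Compounds 1 and 2 gave no hint of this, since their values could not be told apart, whereas this step shows that inhibition is highly sensitive to the group at this place on the six-membered aromatic ring of carbon only, even though the exchange adds only carbon and brings no ring, hydrogen-bond donor, hydrogen-bond acceptor or net charge. Nothing available here accounts for the size of this step.

This single step leaves open whether the gain builds gradually through an intermediate group such as ethyl or isopropyl or requires tert-butyl itself, and whether a cyclohexyl ring or an amine at the same place would serve as well. It also leaves open whether tert-butyl would bring a similar gain with the other ether group carried by compound 2.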